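The source may hold more compounds than are shown below. What is called first, only, known or untested is meant among the compounds shown, and "the series" means these compounds.

Compound 1 `CCCCCCCCCSC[C@H](NC(C)=O)C(=O)CCl`: in a functional assay on MOLT-3 cells (Homo sapiens) (a higher number here means a weaker inhibitor, a lower number a stronger inhibitor), compound 1 gives 6700 nM.
Compound 2 `CCCCCCCCCCCSC[C@H](NC(C)=O)C(=O)CCl`: in this assay compound 2 gives 3000 nM.
Compound 3 `CCCCCCCCCCCCCSC[C@H](NC(C)=O)C(=O)CCl`: in this assay compound 3 gives only a limit, > 100000 nM.

Compound 3 thus sits at the limit of > 100000 nM in this assay, at which 1 of the 3 values shown sits, the weakest position the numbers allow. The step to compound 4 `CCCCCCCCCCCCCCSC[C@H](NC(C)=O)C(=O)CCl` is methyl in place of hydrogen on a saturated chain carbon, ten or more bonds along the chain from a sulfur, one further lengthening of the same chain. Going by the values given here, the steps that bear on it run in opposite directions: a 2.2-fold lower number from compound 1 to compound 2 (0.35 log units; beyond the scatter), but an at least 14-fold higher number from compound 1 to compound 3 (1.17 log units; beyond the scatter) and an at least 33-fold higher number from compound 2 to compound 3 (1.52 log units; beyond the scatter). The longer extensions point to weaker inhibition, and the change here continues beyond compound 3, so in this assay the expected outcome is again a limit rather than a number, with a step that the limit leaves unreadable from compound 3 to compound 4 as the nominal step. Compound 4 is estimated at 150000 nM, within 50000 nM to 600000 nM.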

Compound 4, half-maximal inhibitory concentration: 8800 nM
For compound 4 the middle estimate is 17-fold (1.23 log units) above the measured one, outside the stated range (below it).
By their numbers in this assay, from the lowest: compound 2; then compounds 1 and 4 (each within the scatter of the next). At a limit, above all of these: compound 3.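

In this assay the loss at compound 3 does not carry on along the chain: an at least 11-fold lower number from compound 3 to compound 4 (1.05 log units; beyond the scatter), a step read against a limit, and a measured value returns. Against the shorter chains the result is a 2.9-fold higher number from compound 2 to compound 4 (0.47 log units; beyond the scatter), and a 1.3-fold higher number from compound 1 to compound 4 (0.12 log units; within the scatter), so compound 2 remains the strongest of the four and lengthening follows no single direction. Compound 3 stands as a limit, not a number: the limit of > 100000 nM in this assay, at which 1 of the 4 values shown sits.

Open, on these data alone, is whether a longer chain than that of compound 4 keeps a measured value. Also open, as far as these compounds go, is how an amine at the chain end would read in this assay.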